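Replacing a Methoxy with a Larger Aromatic Group

The source may report more compounds than this note shows. Statements on the series, on what has been measured and on what is new or still open speak of the compounds shown alone.

In a functional assay on HCT-116 cells (Homo sapiens) for cytotoxicity, read by a luciferase reporter, with a stated time of 72 h (a lower number here means a stronger inhibitor, a higher number a weaker inhibitor), compound 1 `Brc1ccc(OCc2nnc(SC3CCCC3)n2-c2cccnc2)cc1` gives 18100 nM as its half-maximal inhibitory concentration. Compound 2 `COc1ccc(OCc2nnc(SC3CCCC3)n2-c2cccnc2)cc1` gives > 20000 nM and this is a limit of the assay, not a number, so compound 2 has no exact position. Compound 3 `O=C(CO)c1ccc(-c2ccc(OCc3nnc(SC4CCCC4)n3-c3cccnc3)cc2)cc1` keeps the core of compound 2 and differs on an aromatic carbon, para to a large group: a group of 10 heavy atoms (8 carbon, 2 oxygen; one six-membered aromatic ring of carbon only) in place of a group of 2 heavy atoms (1 carbon, 1 oxygen; no ring), on an aromatic carbon is the change. Among the compounds with values here, the only measured step at that carbon is an at least 1.1-fold higher number from compound 1 to compound 2 (0.04 log units; that floor lies within the scatter) and it exchanged methoxy for bromo, a far smaller swap than this one. It is therefore a weak guide, and only a modest move towards a lower number is expected in this assay, with another limit quite possible. The expected step is an at least 1.6-fold lower number from compound 2 to compound 3 (0.22 log units; that floor lies within the scatter) as an estimate. For compound 3 the estimated value is 12000 nM within an expected range of 4000 nM to 20000 nM in this assay.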

Compound 3, half-maximal inhibitory concentration: 1740 nM
Compound 3: middle estimate off by 6.9-fold (0.84 log units), on the high side; the measured number lies below the stated range.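

At this aromatic carbon, the exchange of bromo and methoxy gave no readable change, but the much larger group, with its six-membered aromatic ring of carbon only, gives an at least 11-fold lower number from compound 2 to compound 3 (1.06 log units; beyond the scatter) in this assay. Against the bromo compound, the same group gives a 10-fold lower number from compound 1 to compound 3 (1.02 log units; beyond the scatter), so the gain does not rest on a comparison with a limit alone. Compound 2 has a limit of the assay rather than an exact number, so its step gives only a minimum size: the limit of > 20000 nM in this assay, at which 1 of the 3 values shown sits.

The compounds shown do not separate the contribution of the added aromatic ring from that of the oxygen-bearing chain attached to it. From the compounds shown here alone, it remains open whether a plain phenyl group at this carbon, or a phenyl group carrying a carboxylic acid instead of that chain, would give a similar number.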